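Chloro for fluoro on a shared pyrimidine-hydrazone scaffold

The source may hold more compounds than are shown below. What is called first, only, known or untested is meant among the compounds shown, and "the series" means these compounds.

Of the compounds shown here, three have been measured and a fourth awaits measurement. Compound 1, with the structure `C/C(=N/NC(=O)Nc1nc(-c2ccc(F)cc2)cc(-c2ccc([N+](=O)[O-])cc2)n1)c1ccc(C)cc1`, was tested in a functional assay on the whole organism (strain Albino) with Mus musculus as the target, with a stated time of 0.5 h (a higher number here means that more compound is needed for the effect, a lower number that less compound is needed), and compound 1 gives 100 mg/kg. Compound 3, with the structure `C/C(=N/NC(=O)Nc1nc(-c2ccc(Cl)cc2)cc(-c2ccc([N+](=O)[O-])cc2)n1)c1ccc(C)cc1`, differs from compound 1 by chloro in place of fluoro on an aromatic carbon and in this assay compound 3 gives 300 mg/kg. That single change produced a 3.0-fold higher number from compound 1 to compound 3 (0.48 log units; beyond the scatter).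

Compound 2, with the structure `C/C(=N/NC(=O)Nc1nc(-c2ccc(C)cc2)cc(-c2ccc(F)cc2)n1)c1ccc([N+](=O)[O-])cc1`, is built from the same atoms as compound 1, joined differently; how the two cores differ is not broken down here. In this assay compound 2 gives 100 mg/kg, which stands level with compound 1 at the digits printed, and both sit below compound 3.

Compound 4, with the structure `C/C(=N/NC(=O)Nc1nc(-c2ccc(C)cc2)cc(-c2ccc(Cl)cc2)n1)c1ccc([N+](=O)[O-])cc1`, has not yet been measured. It differs from compound 2 by chloro in place of fluoro on an aromatic carbon. The surroundings of the exchanged atom are the same word for word as in the move from compound 1 to compound 3, so this is the same change, applied to the core of compound 2 rather than that of compound 1.

Among the compounds with values here, because a 3.0-fold higher number from compound 1 to compound 3 (0.48 log units; beyond the scatter) is the only measured example of this change, the expected step is taken as a 3.0-fold higher number from compound 2 to compound 4 (0.48 log units; beyond the scatter), matching it. On that basis compound 4 is expected to give about 300 mg/kg in this assay, within a range of 100 mg/kg to 900 mg/kg. Because this rests on one pair only, the range is kept wide.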

Compound 4, dose for half-maximal effect: 100 mg/kg
Estimate against measurement, compound 4: 3.0-fold (0.48 log units) above; the measured number falls inside the stated range.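

On the core of compound 2, chloro in place of fluoro, read as 4-fluorophenyl to 4-chlorophenyl, gives no change at the digits printed from compound 2 to compound 4 (within the scatter) in this assay. The change therefore did not carry over from one core to the other with the same size, and the two measured cases differ: the same change on two cores in this assay, a 3.0-fold higher number (0.48 log units; beyond the scatter) from compound 1 to compound 3 and no change at the digits printed (within the scatter) from compound 2 to compound 4, 3.0-fold (0.48 log units) apart, beyond the scatter of two such steps. Within the data shown here, this shows that, in this series, the step measured on one core cannot simply be transferred to the other, but it does not show why the two cores behave differently, and with only one pair on each core it cannot tell which of the two results is the more typical for this exchange.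

The compounds shown leave open how other groups would behave at the same aromatic carbon, for instance bromo, methoxy or an amine, and whether those would also depend on the core they sit on. They also leave open whether a further core, or a carboxylic acid in place of the nitro group, would follow the pattern of the core of compound 1, that of the core of compound 2, or neither.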